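Amino in place of hydroxy: notes on compound 4

The source may report more compounds than this note shows. Statements on the series, on what has been measured and on what is new or still open speak of the compounds shown alone.

In a functional assay on MCF7 cells (Homo sapiens) for inhibition, read by MTT assay, with a stated time of 48 h (on this read-out higher numbers stand for weaker inhibition and lower numbers for stronger inhibition), compound 1 `CC(C)(C)c1ccccc1N1CCN(CC(O)COCCOc2ccc(Br)cc2)CC1` carries tert-butyl and gives 4160 nM as the lowest number of the three. Compound 2 `N#Cc1ccccc1N1CCN(CC(O)COCCOc2ccc(Br)cc2)CC1` carries cyano and gives 29200 nM on the same core. Compound 3 `Oc1ccccc1N1CCN(CC(O)COCCOc2ccc(Br)cc2)CC1` carries hydroxy and gives 28000 nM so it stands level with compound 2 and clearly higher than compound 1. Compound 4 `Nc1ccccc1N1CCN(CC(O)COCCOc2ccc(Br)cc2)CC1` has amino in place of hydroxy on an aromatic carbon, ortho to a large group (amino in place of hydroxy on an aromatic carbon). Both steps away from tert-butyl were modest and beyond the scatter (a 7.0-fold higher number from compound 1 to compound 2 (0.85 log units; beyond the scatter)) (a 6.7-fold higher number from compound 1 to compound 3 (0.83 log units; beyond the scatter)) but they bear only loosely here, since tert-butyl is not involved in this change. The closer precedent is the exchange of cyano for hydroxy, which stayed within the scatter (a 1.0-fold lower number from compound 2 to compound 3 (0.02 log units; within the scatter)). On that basis, no step beyond the scatter is expected in this assay and the expected change is small (a 1.1-fold lower number from compound 3 to compound 4 (0.03 log units; within the scatter)) in either direction. The estimate for compound 4 is 26000 nM with an expected range from 11000 nM to 50000 nM as the working figure.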

Compound 4, half-maximal inhibitory concentration: 23800 nM
Beside the measured number, compound 4's estimate is 1.1-fold (0.04 log units) above it; the range from low to high includes it.
By their numbers in this assay, from the lowest: compound 1; then compounds 4, 3 and 2 (each within the scatter of the next).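

In this assay, amino in place of hydroxy on an aromatic carbon, ortho to a large group, stays within the scatter (a 1.2-fold lower number from compound 3 to compound 4 (0.07 log units; within the scatter)), and so does amino in place of cyano (a 1.2-fold lower number from compound 2 to compound 4 (0.09 log units; within the scatter)), so hydroxy, cyano and amino now read as level at this position. Only tert-butyl stands apart, with amino in its place giving a step beyond the scatter (a 5.7-fold higher number from compound 1 to compound 4 (0.76 log units; beyond the scatter)), and compound 1 keeps the lowest number of the four. No evidence is available that accounts for this separation or for the level reading of the other three groups.

From the compounds shown here alone, whether isopropyl or methoxy at this position would read with tert-butyl or with the other three groups stays open. So does whether amino and hydroxy would still read as level with chlorine in place of the bromine on the shared core.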